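One double bond of compound 1, from E to Z

This account rests on a few compounds, and the source may have more. Where it says the series, first, only, none or still open, it means among the compounds named here.

- compound 1 `COc1ccc(CS/C=C/C[S+]([O-])Cc2ccc(OC)cc2)cc1`: > 200000 nM (a limit, not a number)
- compound 2 `CCCSS/C=C\C[S+]([O-])CCC`: 18000 nM
- compound 3 `COc1ccc(CSSC=CC[S+]([O-])Cc2ccc(OC)cc2)cc1`: 2100 nM

These results come from a functional assay on WHCO1 cells (Homo sapiens) for antiproliferative activity, read by MTT assay, with a stated time of 48 h; on this read-out higher numbers stand for weaker inhibition and lower numbers for stronger inhibition. Compound 1 sits at the limit of > 200000 nM in this assay, at which 1 of the 3 values shown sits, so it has a limit and no exact number. Compound 4 `COc1ccc(CS/C=C\C[S+]([O-])Cc2ccc(OC)cc2)cc1` has the same atoms and bonds as compound 1: the two compounds have the same atoms and bonds; at least one stereo element is drawn with a configuration in one of them and without one in the other: 1 of 2 stereo elements differ; a double bond is drawn E in compound 1 and Z in compound 4. Within the data shown here, compound 2 and compound 3 give numbers, but no measured pair isolates this change of double-bond geometry. A modest move towards stronger inhibition in this assay is therefore expected, and compound 4 may well stay near the limit. The expected step is an at least 1.3-fold lower number from compound 1 to compound 4 (0.12 log units; that floor lies within the scatter). For compound 4 the estimated value is 150000 nM, with an expected range from 50000 nM to 400000 nM.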

Compound 4, half-maximal inhibitory concentration: > 200000 nM
Compound 4 ended at the assay's limit (the forecaster's own chance of this, stated with the estimate: 55%); middle value at least 1.3-fold (0.12 log units) from the limit.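

Compound 1 and compound 4 both end at a limit rather than a number, so no step between them can be read: the limit of > 200000 nM in this assay, at which 2 of the 4 values shown sit.

The compounds shown leave open whether the geometry of this double bond affects inhibition at all.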